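Aryloxy variation on the phosphoserine ester series

A few compounds are considered here, and "the series" means these few. Any claim that something is new, unique, unknown or untested is made for them only; others in the source may bear on it.

Measured compounds:
compound 1 `N[C@@H](COP(=O)(O)OCCCOC(=O)CCc1ccccc1OCc1cccc(Oc2ccccc2Cl)c1)C(=O)O`: 19.8%
compound 2 `N[C@@H](COP(=O)(O)OCCCOC(=O)CCc1ccccc1OCc1cccc(Oc2cccc(Cl)c2)c1)C(=O)O`: 17.1%
compound 3 `N[C@@H](COP(=O)(O)OCCCOC(=O)CCc1ccccc1OCc1cccc(Oc2ccc(F)cc2)c1)C(=O)O`: 18.7%

In an assay on cells for agonist activity at probable G-protein coupled receptor 34 (Mus musculus), with a stated time of 1 h (on this read-out higher numbers stand for larger maximal responses and lower numbers for smaller maximal responses), compound 1 gives 19.8%, compound 2 gives 17.1% and compound 3 gives 18.7%. Compound 3 is the second highest of the three numbers, but all three sit within the scatter of one another: a number 1.1 percentage points lower from compound 1 to compound 3 (within the scatter) and a number 1.6 percentage points higher from compound 2 to compound 3 (within the scatter), and likewise a number 2.7 percentage points lower from compound 1 to compound 2 (within the scatter). Moving a chlorine around the phenoxy ring or trading it for fluorine therefore does nothing that the assay can resolve.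

Compound 4 `CC(C)(C)c1ccc(Oc2cccc(COc3ccccc3CCC(=O)OCCCOP(=O)(O)OC[C@H](N)C(=O)O)c2)cc1` is the next member. Its difference from compound 3 is tert-butyl in place of fluoro on an aromatic carbon. For the measured compounds named here, the steps that bear on it are those that already touch the phenoxy substituent, the ones from compound 1 and compound 2 to compound 3, and both were flat. Going by the values given here, no measured compound carries tert-butyl or any group of comparable size at this position, so the expectation rests on the flat steps alone, with a wider range to cover the untested group. Compound 4 is expected to give 18%, within 7% to 32%, a step of a number 0.7 percentage points lower from compound 3 to compound 4 (within the scatter) that is expected to stay within the scatter.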

Compound 4, largest response reached (Emax), in percent of the reference or control that the assay uses: 16.9%
Compound 4: the middle estimate sits 1.1 percentage points above what was measured; low and high end bracket the measured number.
By their numbers in this assay, from the lowest: compounds 4, 2, 3 and 1 (each within the scatter of the next).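

In this assay the change from fluoro to tert-butyl, 4 heavy atoms in place of 1 heavy atom on the same aromatic carbon, gives a number 1.8 percentage points lower from compound 3 to compound 4 (within the scatter), so this position tolerates a far bulkier all-carbon group with no change the assay can resolve. The chlorinated compounds read the same way, with a number 0.2 percentage points lower from compound 2 to compound 4 (within the scatter) and a number 2.9 percentage points lower from compound 1 to compound 4 (within the scatter), which leaves all four compounds within the scatter of one another and extends the flat range from halogens to a branched alkyl group. Nothing available here offers an explanation for this flat response.

On these data alone, whether an amine, a carboxylic acid or a hydroxyl on this phenoxy ring would lift the response clear of the scatter stays open. As far as these compounds go, the shared core is the same throughout, so the effect of a longer chain between its ester and phosphate also remains open.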